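The source may hold more compounds than are shown below. What is called first, only, known or untested is meant among the compounds shown, and "the series" means these compounds.

In a functional assay on K562 cells (Homo sapiens) for inhibition, read by MTT assay, with a stated time of 72 h (a higher number here means a weaker inhibitor, a lower number a stronger inhibitor), compound 1 `CCc1ccc(C(=O)/C=C/C(=O)O)cc1` gives 5530 nM and compound 2 `CC(C)c1ccc(C(=O)/C=C/C(=O)O)cc1` gives 5560 nM while compound 3 `CCCCc1ccc(C(=O)/C=C/C(=O)O)cc1` gives 4950 nM on the same read-out. Compound 3 thus stands level with the other two, its number within the scatter of both.

Compound 4 `CC(C)(C)c1ccc(C(=O)/C=C/C(=O)O)cc1` has the same atoms as compound 3, joined differently: tert-butyl in place of butyl on an aromatic carbon is the whole difference, tert-butyl in place of butyl on an aromatic carbon. The closest measured precedent is a 1.1-fold lower number from compound 2 to compound 3 (0.05 log units; within the scatter) as the group on that same aromatic carbon changes, and it lies within the scatter. The other two steps, a 1.0-fold higher number from compound 1 to compound 2 (0.00 log units; within the scatter) and a 1.1-fold lower number from compound 1 to compound 3 (0.05 log units; within the scatter) as well, stay within the scatter too.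

None of the three measured compounds carries a tert-butyl group, so this precedent is indirect. Even so, no step beyond the scatter is expected in this assay for this change. The estimated step is a 1.1-fold higher number from compound 3 to compound 4 (0.03 log units; within the scatter) and it is expected to stay within the scatter, with no clear direction. For compound 4 the expected value is 5300 nM with an estimated range from 3500 nM to 8000 nM as the span of likely readings.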

Compound 4, half-maximal inhibitory concentration: 4330 nM
Estimate against measurement, compound 4: 1.2-fold (0.09 log units) above; the range from low to high includes it.
By their numbers in this assay, from the lowest: compounds 4, 3, 1 and 2 (each within the scatter of the next).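

In this assay the same carbons joined differently on the aromatic carbon, tert-butyl in place of butyl, give a 1.1-fold lower number from compound 3 to compound 4 (0.06 log units; within the scatter) and so show that, at this place para to a group of 7 heavy atoms, this rearrangement of the butyl chain does not carry the reading beyond the scatter. The tert-butyl group also stays level with the smaller groups, with a 1.3-fold lower number from compound 2 to compound 4 (0.11 log units; within the scatter) for the added methyl on the saturated chain carbon and a 1.3-fold lower number from compound 1 to compound 4 (0.11 log units; within the scatter) for tert-butyl in place of ethyl, so that ethyl, isopropyl, butyl and tert-butyl on this carbon now all read alike, a flat stretch that reaches a more heavily branched group than the other three compounds carried. Nothing at hand accounts for this flatness.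

All four groups are saturated carbon chains, which leaves open whether an amine, a methoxy group, a carboxylic acid or a longer chain such as octyl on the same aromatic carbon would also stay level. Every compound shown also keeps the carboxylic acid of the shared core, so what a methyl ester or an amide in its place would do to the number remains open.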